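Hydrogen in place of methoxy on compound 1

This account rests on a few compounds, and the source may have more. Where it says the series, first, only, none or still open, it means among the compounds named here.

In a functional assay on the whole organism (strain Kunming) with Mus musculus as the target, with a stated time of 0.5 h (on this read-out lower numbers stand for an effect already at smaller amounts and higher numbers for an effect only at larger amounts of compound), compound 1 (`COc1cc(OC)c(OC)cc1/C=C/COC(=O)/C=C/c1ccc(OC)c(OC)c1`) gives 173 mg/kg and stands within the scatter of compound 2 (`COc1cc(OC)c(OC)cc1/C=C/COC(=O)/C=C/c1c(OC)ccc(OC)c1OC`) at 212 mg/kg and of compound 3 (`COc1cc(OC)c(OC)cc1/C=C/COC(=O)/C=C/c1cc(OC)c(OC)c(OC)c1`) at 204 mg/kg on these numbers. Compound 4 (`COc1ccc(/C=C/C(=O)OC/C=C/c2cc(OC)c(OC)cc2OC)cc1`) has not yet been measured. It differs from compound 1 by hydrogen in place of methoxy on an aromatic carbon in a change of 3,4-dimethoxyphenyl to 4-methoxyphenyl. Within the data shown here, the one measured step of this kind runs the other way, with methoxy entering rather than leaving, and shows a 1.2-fold higher number from compound 1 to compound 3 (0.07 log units; within the scatter) as its size. No step beyond the scatter is therefore expected in this assay here. The expected step is a 1.0-fold higher number from compound 1 to compound 4 (0.00 log units; within the scatter) by this estimate. The estimated value for compound 4 is 175 mg/kg (range 100 mg/kg to 300 mg/kg).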

Compound 4, dose for half-maximal effect: 244 mg/kg
Estimate against measurement, compound 4: 1.4-fold (0.14 log units) below; low and high end bracket the measured number.
By their numbers in this assay, from the lowest: compounds 1, 3, 2 and 4 (each within the scatter of the next).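

Taking one methoxy away from the ring of compound 1, turning 3,4-dimethoxyphenyl into 4-methoxyphenyl, gives in this assay a 1.4-fold higher number from compound 1 to compound 4 (0.15 log units; within the scatter) and so stays within the scatter. With a 1.2-fold higher number from compound 1 to compound 3 (0.07 log units; within the scatter) as the step for an added methoxy, neither removing nor adding this group on that ring moves the number beyond the scatter. No measurement here offers an explanation for this.

The compounds shown leave open whether an amine, a carboxylic acid or a longer alkoxy chain on this aromatic carbon would give a step beyond the scatter.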